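This account rests on a few compounds, and the source may have more. Where it says the series, first, only, none or still open, it means among the compounds named here.

In an assay on isolated protein for inhibition of RAC-alpha serine/threonine-protein kinase (Homo sapiens), read by mobility shift assay, tested at 30 uM (a lower number here means less inhibition, a higher number more inhibition at the concentration tested (going by the name of the read-out)), this series stays close to the floor throughout. Compound 1 `COc1cccc(-c2cc3[nH]nc(N)c3c(=O)[nH]2)c1` gives 4%, compound 2 `Cn1nc(N)c2c(=O)[nH]c(-c3ccccc3)cc21` gives 8%, and compound 3 `Cn1nc(N)c2c(=O)[nH]c(-c3ccccn3)cc21` gives 7%. Compound 2 has the highest of the three numbers, yet its nearest neighbour, compound 3, lies only a number 1 percentage points lower from compound 2 to compound 3 (within the scatter) away, and compound 1 sits a little lower still; both gaps fall within the scatter, so nothing separates the three.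

For the measured compounds named here, the single measured step, from compound 2 to compound 3, swaps pyridin-2-yl for phenyl and changes nothing beyond the scatter. The step now followed, from compound 2 to compound 4 `COc1cccc(-c2cc3c(c(N)nn3C)c(=O)[nH]2)c1`, is different in kind: methoxy in place of hydrogen on an aromatic carbon. Going by the values given here, no measured pair isolates this change. Compound 1, which carries the same methoxy group but lacks the methyl on the pyrazole nitrogen, shows a value no different within the scatter from compound 2, so the two values together offer no sign that the methoxy group moves this assay.

Given that, compound 4 is expected to remain at the floor, with an estimated step of a number 2 percentage points lower from compound 2 to compound 4 (within the scatter). In this assay compound 4 is estimated at 6%, within a range from -2% to 15%.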

Compound 4, a percentage reported as inhibition, at one concentration (the size of the read-out at that concentration, not a potency): -5%
For compound 4 the middle estimate is 11 percentage points above the measured one; the whole stated range lies above it.
By their numbers in this assay, from the lowest: compounds 4, 1, 3 and 2 (each within the scatter of the next, the first and the last beyond it).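

In this assay, for the compounds shown here, the methoxy group, on an aromatic carbon of the six-membered aromatic ring of carbon only and meta to a large group, gives the first step to leave the scatter: a number 13 percentage points lower from compound 2 to compound 4 (beyond the scatter) is a modest move towards less inhibition, which the swap of phenyl for pyridin-2-yl did not produce. The other new comparison keeps the methoxy group in place and puts methyl in place of hydrogen on an aromatic nitrogen, and a number 9 percentage points lower from compound 1 to compound 4 (within the scatter) shows that this change cannot be told from no change at all. No measurement given here bears on why the methoxy step runs in this direction.

All four compounds stay near the floor, so the series shows only that methoxy at this position brings no gain in inhibition, not whether any group there could bring one. As far as these compounds go, whether an amine, a carboxylic acid or a longer chain such as ethoxy on the same aromatic carbon would lift the number clear of the floor remains open.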